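The source may report more compounds than this note shows. Statements on the series, on what has been measured and on what is new or still open speak of the compounds shown alone.

Working notes on the series.

Compound 1, `NC(=O)Cn1c(=O)n(C2OC(CO)[C@@H](O)[C@H]2O)c2nc(N)nc(O)c21`, is the reference point of this set. Going by the values given here, in a functional assay on the whole organism (B cells) with Mus musculus as the target (a lower number here means a smaller maximal response, a higher number a larger maximal response), compound 1 gives 32%, the lowest of the two values measured so far. Compound 2, `CCCn1c(=O)n(C2C=CC(CO)O2)c2nc(N)nc(O)c21`, gives 118% in this assay, and the gap between compound 1 and compound 2 lies beyond the scatter. Compound 2 differs from compound 1 in more than one place, so no single step can be read from that pair; only the two values themselves are known.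

Compound 3, `[N-]=[N+]=NCC(O)Cn1c(=O)n(C2OC(CO)[C@@H](O)[C@H]2O)c2nc(N)nc(O)c21`, is not yet measured. It differs from compound 1 in one place: 2-azido-1-hydroxyethyl in place of carbamoyl on a saturated chain carbon bound to an aromatic nitrogen. Among the compounds with values here, no step between two measured compounds covers this change, so the expected step from compound 1 to compound 3 rests on the change alone and on the fact that compound 2, with a larger chain on the same aromatic nitrogen, gives 118%. A moderate upward step is expected, a number 18 percentage points higher from compound 1 to compound 3 (beyond the scatter), with wide uncertainty. For compound 3 the estimated value in this assay is 50%, expected to fall between 20% and 95%.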

Compound 3, largest response reached (reported as maximal response), in percent of the reference or control that the assay uses: 91%
Estimate against measurement, compound 3: 41 percentage points below, within the range that was stated.
By their numbers in this assay, from the lowest: compound 1; then compound 3; then compound 2.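

Going by these compounds alone, the chain on the aromatic nitrogen matters on its own: with the rest of compound 1 unchanged, 2-azido-1-hydroxyethyl in place of carbamoyl on a saturated chain carbon bound to an aromatic nitrogen gives a number 59 percentage points higher from compound 1 to compound 3 (beyond the scatter) in this assay and is the only single-place step read so far. Read one bond further out, this change is carbamoylmethyl to 3-azido-2-hydroxypropyl, and the entering group has more heavy atoms and more hydrogen-bond acceptors than the leaving one, with the same count of hydrogen-bond donors. No supporting measurement bears on the origin of this step.

The azido group and the hydroxyl enter together in this one change, so the compounds shown leave open which of them carries the step, and a plain 2-hydroxypropyl chain or a 3-amino-2-hydroxypropyl chain on the same aromatic nitrogen would bear on that. Also open, from the compounds shown here alone, is whether a carboxylic acid or a longer alkyl chain at this place would shift the maximal response as far.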